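Acetylating the oxime oxygen of compound 1

This account rests on a few compounds, and the source may have more. Where it says the series, first, only, none or still open, it means among the compounds named here.

Compound 1 `COc1ccc(/C(=N/O)c2cccc3ccccc23)c(OC)c1OC` gives 13100 nM in a functional assay on A549 cells (Homo sapiens) for inhibition, read by sulforhodamine B assay, with a stated time of 48 h; a lower number here means a stronger inhibitor, a higher number a weaker inhibitor. Its number is the smallest of the three measured, but the gaps to its neighbours are within the scatter: the benzyl ether compound 2 `COc1ccc(C(OCc2ccccc2)c2cccc3ccccc23)c(OC)c1OC` gives 13500 nM in this assay, and compound 3 `COc1cc(COC(c2ccc(OC)c(OC)c2OC)c2cccc3ccccc23)cc(OC)c1` gives 17500 nM. For the measured compounds named here, the single measured step, a 1.3-fold higher number from compound 2 to compound 3 (0.11 log units; within the scatter), swaps the aryl group of the ether and leaves the number essentially unchanged.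

Compound 4 `COc1ccc(/C(=N/OC(C)=O)c2cccc3ccccc23)c(OC)c1OC` differs from compound 1 by acetyl in place of hydrogen on an oxygen, the hydroxy becoming an acetoxy. Going by the values given here, no measured step touches the oxime oxygen, so nothing measured bears on this change directly; the only step on record, from compound 2 to compound 3, shows that a peripheral substitution on this core leaves this assay flat. The working expectation is therefore a step of a 1.0-fold lower number from compound 1 to compound 4 (0.00 log units; within the scatter), that is, no change beyond the scatter. Compound 4 is estimated at 13000 nM, with a range from 4500 nM to 38000 nM.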

Compound 4, half-maximal inhibitory concentration: 17200 nM
For compound 4 the middle estimate is 1.3-fold (0.12 log units) below the measured one, and the stated range covers the measured number.
By their numbers in this assay, from the lowest: compounds 1, 2, 4 and 3 (each within the scatter of the next).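

In this assay, for the compounds shown here, acetyl in place of hydrogen on the oxygen bound to the double-bonded nitrogen gives a 1.3-fold higher number from compound 1 to compound 4 (0.12 log units; within the scatter) and so provides the first measured change at this position. Capping the hydroxy as an acetoxy therefore does not move the number beyond the scatter, and the free hydroxy hydrogen is not needed for a value of this size in this assay. Nothing on hand gives a reason for this result.

Going by these compounds, whether this oxygen tolerates other groups remains open: a methyl ether, a benzoyl ester or a longer chain ending in an amine could each behave differently from acetyl. Going by these compounds alone, with only two steps readable, both within the scatter, it also remains open which change to the shared core would shift the number beyond the scatter.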